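The source may report more compounds than this note shows. Statements on the series, on what has been measured and on what is new or still open speak of the compounds shown alone.

Measured in a functional assay on DU-145 cells (Homo sapiens) for inhibition, read by MTT assay, with stated times of 18 h and 4 h; a higher number here means a weaker inhibitor, a lower number a stronger inhibitor:
- compound 1 `CCCCCCCCCCCCCCCCOP(=O)(O)OCCSC(=S)N1CCCCCC1`: 17600 nM
- compound 2 `CCCCCCCCCCOP(=O)(O)OCCSC(=S)N1CCCCCC1`: 24000 nM

These two values do not separate the compounds, so compound 1 holds no clear rank. For the measured compounds named here, the only measured step is a 1.4-fold higher number from compound 1 to compound 2 (0.13 log units; within the scatter), and it places hydrogen in place of hexyl on a saturated chain carbon.

The next compound, compound 3 `CCCCCCCCCCCCCCCCOP(=O)(O)OCCSC(=S)N1CCN(C)CC1`, leaves that chain as it is in compound 1. Its change lies elsewhere, with 4-methylpiperazin-1-yl in place of azepan-1-yl on a thiocarbonyl carbon. Going by the values given here, no measured compound tests a change at this place, so the chain step gives only indirect guidance. It shows how little the values moved for one edit, but it cannot show what a different group on the thiocarbonyl carbon will do.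

With compound 1 at 17600 nM as the starting point and no measured evidence for a direction, no step beyond the scatter is expected in this assay, though the basis is thin and the range must stay wide. The expected step is a 1.1-fold higher number from compound 1 to compound 3 (0.06 log units; within the scatter). The estimate for compound 3 is 20000 nM, with an expected range from 8000 nM to 50000 nM.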

Compound 3, half-maximal inhibitory concentration: 49300 nM
Compound 3: middle estimate off by 2.5-fold (0.39 log units), on the low side; measured number inside the range.
By their numbers in this assay, from the lowest: compounds 1 and 2 (each within the scatter of the next); then compound 3.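

For the compounds shown here, on the thiocarbonyl carbon, the group does affect the result in this assay: placing 4-methylpiperazin-1-yl where azepan-1-yl stood gives a 2.8-fold higher number from compound 1 to compound 3 (0.45 log units; beyond the scatter), whereas the only earlier step, on the chain, gave a 1.4-fold higher number from compound 1 to compound 2 (0.13 log units; within the scatter). The two groups have the same number of heavy atoms, so this step does not come with a change in that count, but several other features change at once: a seven-membered ring with 1 hetero atom becomes a six-membered ring with 2 hetero atoms, and the hydrogen-bond acceptor count rises from 0 to 1. No measurement here explains the step, and a single pair of compounds cannot show which of these differences matters.

The compounds shown leave open whether ring size or the second ring nitrogen accounts for the step; piperidin-1-yl, a six-membered ring with only one nitrogen, would help to separate the two. Also open, going by these compounds, is whether the same exchange would produce a step of similar size on the shorter chain of compound 2.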